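This account rests on a few compounds, and the source may have more. Where it says the series, first, only, none or still open, it means among the compounds named here.

Measured so far in an ADME assay on THP-1 cells (Homo sapiens) for cytotoxicity; on this read-out higher numbers stand for weaker inhibition and lower numbers for stronger inhibition: compound 1 `COc1ccccc1-c1nnc(-c2ccc(C(=O)N/N=C/c3cccc(O)c3)cc2)o1` gives 398000 nM; compound 2 `COc1ccccc1-c1nnc(-c2ccc(C(=O)N/N=C/c3cccc(O)c3O)cc2)o1` gives 102000 nM.

Among the measured compounds shown here, compound 2 shows the lowest of the two numbers; the only comparison is a 3.9-fold lower number from compound 1 to compound 2 (0.59 log units; beyond the scatter), a step beyond the scatter.

Compound 3 `COc1ccccc1-c1nnc(-c2ccc(C(=O)N/N=C/c3ccc(O)cc3)cc2)o1` differs from compound 2 by 4-hydroxyphenyl in place of 2,3-dihydroxyphenyl on a carbon with a double bond to nitrogen. For the measured compounds named here, only one measured step bears on it: a 3.9-fold lower number from compound 1 to compound 2 (0.59 log units; beyond the scatter) shows that adding a hydroxy on an aromatic carbon gave a modest drop. Compound 3 carries a single hydroxy, as compound 1 does, so the step is expected to run back toward compound 1, i.e. a modest rise in this assay.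

For compound 3 the expected value is 300000 nM (range 100000 nM to 700000 nM), meaning an expected step of a 2.9-fold higher number from compound 2 to compound 3 (0.47 log units; beyond the scatter).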

Compound 3, half-maximal inhibitory concentration: 261000 nM
Compound 3: middle estimate off by 1.1-fold (0.06 log units), on the high side; the measured number falls inside the stated range.
By their numbers in this assay, from the lowest: compound 2; then compounds 3 and 1 (each within the scatter of the next).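

In this assay, 4-hydroxyphenyl in place of 3-hydroxyphenyl gives a 1.5-fold lower number from compound 1 to compound 3 (0.18 log units; within the scatter), so these two single-hydroxy compounds cannot be told apart. By contrast, 4-hydroxyphenyl in place of 2,3-dihydroxyphenyl gives a 2.6-fold higher number from compound 2 to compound 3 (0.41 log units; beyond the scatter). Across these three compounds, the lower number therefore goes with 2,3-dihydroxyphenyl, while the two single-hydroxy groups stay level.

Nothing at hand gives a reason for this difference. Open, on these data alone, is whether an amine or a carboxylic acid in place of a hydroxy would give a number nearer compound 2 or compound 3.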